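A methyl ester at the far end of the chain

This account rests on a few compounds, and the source may have more. Where it says the series, first, only, none or still open, it means among the compounds named here.

Compound 3 `CC(C)(C)C(=O)OCC1(CO)C/C(=C\CCCCCCCCCCCCCCC=O)C(=O)O1` gives in a functional assay on HL-60 cells (Homo sapiens) for antiproliferative activity (a higher number here means a weaker inhibitor of growth, a lower number a stronger inhibitor of growth), only a limit, > 10 ug/mL, the same limit that the limit of > 10 ug/mL in this assay, at which 1 of the 3 values shown sits, describes. Compound 1 `COCCCCCCCCCCCCCCC/C=C1\CC(CO)(COC(=O)C(C)(C)C)OC1=O` gives 4.65 ug/mL in this assay. Compound 2 `CC(C)(C)C(=O)OCCCCCCCCCCCCCCC/C=C1\CC(CO)(COC(=O)C(C)(C)C)OC1=O` gives 7.78 ug/mL. The steps of an at least 2.1-fold higher number from compound 1 to compound 3 (0.33 log units; beyond the scatter) and an at least 1.2-fold higher number from compound 2 to compound 3 (0.10 log units; that floor lies within the scatter) are the only ones that touch the chain end: the formyl terminus reads weaker than the methoxymethyl end, while against the (((tert-butyl)carbonyl)oxy)methyl end the step stays within the scatter. Compound 4 `COC(=O)CCCCCCCCCCCCCC/C=C1\CC(CO)(COC(=O)C(C)(C)C)OC1=O` differs from compound 3 in one place: methoxy in place of hydrogen on a carbonyl carbon. Because compound 1 gives 4.65 ug/mL and compound 2 gives 7.78 ug/mL with oxygen-bearing chain ends, compound 4 is expected to return to a measurable number near them, a step of an at least 1.2-fold lower number from compound 3 to compound 4 (0.09 log units; that floor lies within the scatter). Compound 4 is therefore estimated at 8 ug/mL, between 3 ug/mL and 20 ug/mL.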

Compound 4, concentration for 50% growth inhibition: > 10 ug/mL
Compound 4: a limit, no number; the forecaster's own chance of this, stated with the estimate: 40%; at least 1.2-fold (0.09 log units) between middle value and limit.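

The methoxycarbonyl end shows an at least 2.1-fold higher number from compound 1 to compound 4 (0.33 log units; beyond the scatter) against the methoxymethyl end and an at least 1.2-fold higher number from compound 2 to compound 4 (0.10 log units; that floor lies within the scatter) against the (((tert-butyl)carbonyl)oxy)methyl end. Putting methoxy in place of hydrogen on the carbonyl carbon therefore leaves the chain end on the weak side of methoxymethyl, as formyl was. In this assay compound 4 gives only a limit, as compound 3 does, so the step between them cannot be read: the limit of > 10 ug/mL in this assay, at which 2 of the 4 values shown sit.

On these data alone, whether compound 3 and compound 4 differ at all stays open. As far as these compounds go, how a carboxylic acid or an amine at this chain end would read also stays open.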